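A phenyl for a methyl on a growth inhibitor

The source may report more compounds than this note shows. Statements on the series, on what has been measured and on what is new or still open speak of the compounds shown alone.

compound 1 `Cc1nnc(NC(=O)/C(C#N)=C/c2cccc(OS(C)(=O)=O)c2)s1` gives 20%
compound 2 `Cc1ccc(S(=O)(=O)Oc2cccc(/C=C(\C#N)C(=O)Nc3nnc(C)s3)c2)cc1` gives 71%

In a functional assay on HL-60 cells (Homo sapiens) for inhibition, read by CCK-8 assay, with a stated time of 48 h, tested at 20 uM (on this read-out lower numbers stand for less inhibition of growth and higher numbers for more inhibition of growth at the one concentration tested), compound 2 with 71% stands highest of the two measured compounds. Compound 3 `Cc1ccc(S(=O)(=O)Oc2cccc(/C=C(\C#N)C(=O)Nc3nnc(-c4ccccc4)s3)c2)cc1` differs from it in one place (phenyl in place of methyl on an aromatic carbon) with phenyl in place of methyl on an aromatic carbon, turning 5-methyl-1,3,4-thiadiazol-2-yl into 5-phenyl-1,3,4-thiadiazol-2-yl. Among the measured compounds shown here, the only measured step is a number 51 percentage points higher from compound 1 to compound 2 (beyond the scatter) and it is large and beyond the scatter. That step put 4-methylphenyl in place of methyl on a sulfonyl sulfur, so it also replaced methyl with a larger group, but at another place. No measurement covers the group changing now, so this step is a weak guide. A slight rise in this assay that stays within the scatter is expected, and a fall cannot be excluded. The expected change is a number 4 percentage points higher from compound 2 to compound 3 (within the scatter) and no more. Compound 3 is estimated at 75% with an expected range from 50% to 95% for its measurement.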

Compound 3, percent growth inhibition at one concentration: 63%
Compound 3: the middle estimate sits 12 percentage points above what was measured; the range from low to high includes it.
By their numbers in this assay, from the lowest: compound 1; then compounds 3 and 2 (each within the scatter of the next).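

In this assay, phenyl in place of methyl on the aromatic carbon of the five-membered ring gives a number 8 percentage points lower from compound 2 to compound 3 (within the scatter). This position, next to the ring nitrogen and next to the ring sulfur, therefore carries either group with no difference beyond the scatter, even though phenyl brings a whole aromatic ring. Methyl to a larger group behaves differently at the sulfonyl sulfur, where the change gives a number 51 percentage points higher from compound 1 to compound 2 (beyond the scatter), so the effect of such a swap at one place does not carry over to the other, and nothing shown gives a reason for this result.

On these data alone, whether an amine or a carboxylic acid on this carbon would keep the growth inhibition remains open. So does the reading of the 5-phenyl-1,3,4-thiadiazol-2-yl group with methyl rather than 4-methylphenyl on the sulfonyl sulfur.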